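Isopropoxy in Place of Bromo on a Benzylpiperidine Oxazole Series

The source may report more compounds than this note shows. Statements on the series, on what has been measured and on what is new or still open speak of the compounds shown alone.

Compound 1 `O=C(CCCC1CCN(Cc2cccc(Br)c2)CC1)c1ncco1` gives 10 nM in an assay on isolated protein for inhibition of Fatty-acid amide hydrolase 1 (Homo sapiens); on this read-out lower numbers stand for stronger inhibition and higher numbers for weaker inhibition.
Compound 2 `O=C(CCCC1CCN(Cc2ccc(Br)cc2)CC1)c1ncco1` gives 45 nM in this assay.
Compound 3 `CC(C)Oc1cccc(CN2CCC(CCCC(=O)c3ncco3)CC2)c1` gives 5 nM in this assay.

Three compounds share one core and differ only on the benzyl ring. Compound 2 differs from compound 1 as follows: 4-bromophenyl in place of 3-bromophenyl on a saturated chain carbon bound to an amine nitrogen in a ring. That change made a 4.5-fold higher number from compound 1 to compound 2 (0.65 log units; beyond the scatter), so compound 2 holds the highest number of the three. Compound 3 differs from compound 1 as follows: isopropoxy in place of bromo on an aromatic carbon. That change made a 2.0-fold lower number from compound 1 to compound 3 (0.30 log units; within the scatter).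

Compound 4 `CC(C)Oc1ccc(CN2CCC(CCCC(=O)c3ncco3)CC2)cc1` has not been measured. It differs from compound 2 as follows: isopropoxy in place of bromo on an aromatic carbon. Within the data shown here, this is the same kind of change as the one from compound 1 to compound 3, but the surroundings differ: in compound 3 the isopropoxy sits meta to a large group, in compound 4 para to a large group. Among the measured compounds shown here, the only guide is the step from compound 1 to compound 3, which stayed within the scatter. Resting on a 2.0-fold lower number from compound 1 to compound 3 (0.30 log units; within the scatter), a step of a 2.0-fold lower number from compound 2 to compound 4 (0.31 log units; beyond the scatter) is expected from compound 2 to compound 4 in this assay. Compound 4 is therefore estimated at 22 nM, with a likely range from 8 nM to 60 nM.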

Compound 4, half-maximal inhibitory concentration: 14 nM
Beside the measured number, compound 4's estimate is 1.6-fold (0.20 log units) above it, within the range that was stated.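

In this assay, isopropoxy in place of bromo gave a 3.2-fold lower number from compound 2 to compound 4 (0.51 log units; beyond the scatter), and set beside the earlier step on the other core, the two cannot be told apart: the same change on two cores in this assay, a 2.0-fold lower number (0.30 log units; within the scatter) from compound 1 to compound 3 and a 3.2-fold lower number (0.51 log units; beyond the scatter) from compound 2 to compound 4, 1.6-fold (0.21 log units) apart, within the scatter of two such steps. The change therefore carried from the core of compound 1 to the core of compound 2 with no size difference that the assay can resolve, even though the bromo and the isopropoxy sit at different places on the benzyl ring in the two pairs. This rests on two pairs only, with one step within the scatter and the other beyond it, so it supports agreement between these two cores but gives no rule for the wider series and no explanation of the effect.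

The compounds shown leave open whether a smaller ether such as methoxy, or an amine, would follow the same course at these places on the benzyl ring. They also leave open whether the step would hold on a core with a longer chain.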